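Swapping the anilino aryl group at the quinazoline-free core

The compounds below may be only part of what the source reports. "The series", "measured", "known", "first", "only" and "open" are said of these compounds alone.

Compound 1 `COc1cc2ncnc(Nc3cccc(Cl)c3)c2cc1OCCCCC(=O)Nc1ccc(S(N)(=O)=O)cc1`: 30400 nM
Compound 2 `COc1ccc(Nc2ncnc3cc(OC)c(OCCCCC(=O)Nc4ccc(S(N)(=O)=O)cc4)cc23)cc1`: 14700 nM
Compound 3 `COc1ccc(Nc2ncnc3cc(OC)c(OCCCCC(=O)Nc4ccc(S(N)(=O)=O)cc4)cc23)cc1OC`: 35400 nM

The three measured compounds share a core and differ only in the aryl group on the nitrogen attached to that core. In a functional assay on A-431 cells (Homo sapiens) for antiproliferative activity, read by MTT assay, with a stated time of 72 h (a lower number here means a stronger inhibitor, a higher number a weaker inhibitor), compound 3 gives the highest number of the three; the gap to compound 1 is within the scatter, while the step of a 2.4-fold higher number from compound 2 to compound 3 (0.38 log units; beyond the scatter) is beyond it. Within the data shown here, compound 4 `COc1cc2ncnc(Nc3ccc(C)cc3)c2cc1OCCCCC(=O)Nc1ccc(S(N)(=O)=O)cc1` keeps everything else and changes only that aryl group: 4-methylphenyl in place of 3,4-dimethoxyphenyl on a nitrogen on an aromatic ring.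

Among the measured compounds shown here, two measured steps bear on this change. The step of a 2.1-fold lower number from compound 1 to compound 2 (0.32 log units; beyond the scatter) shows that a 4-methoxyphenyl on this nitrogen gives a modestly lower number than a 3-chlorophenyl, and the step of a 2.4-fold higher number from compound 2 to compound 3 (0.38 log units; beyond the scatter) shows that adding a methoxy to make the 3,4-dimethoxyphenyl raises the number again by a similar amount. Compound 4 carries a 4-methylphenyl, a single group on the ring as in compound 2 rather than two as in compound 3, so a modest decrease of about the size of a 2.4-fold higher number from compound 2 to compound 3 (0.38 log units; beyond the scatter) in reverse is expected, and nothing larger. The estimate for compound 4 is 18000 nM in this assay, with a range from 8000 nM to 40000 nM, which means an expected step of a 2.0-fold lower number from compound 3 to compound 4 (0.29 log units; within the scatter).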

Compound 4, half-maximal inhibitory concentration: 35500 nM
The estimate for compound 4 lay 2.0-fold (0.29 log units) below the measured number; the range from low to high includes it.
By their numbers in this assay, from the lowest: compound 2; then compounds 1, 3 and 4 (each within the scatter of the next).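

In this assay, the 4-methylphenyl group is level with the 3,4-dimethoxyphenyl group (a 1.0-fold higher number from compound 3 to compound 4 (0.00 log units; within the scatter)) and with the 3-chlorophenyl group (a 1.2-fold higher number from compound 1 to compound 4 (0.07 log units; within the scatter)), so having a single group on the aryl ring does not by itself give the lower number. Methyl in place of methoxy on an aromatic carbon gives a modest step (a 2.4-fold higher number from compound 2 to compound 4 (0.38 log units; beyond the scatter)), which leaves the 4-methoxyphenyl group of compound 2 as the only one of the four aryl groups that stands apart, and the lower number goes with that methoxy rather than with the count of groups on the ring. Nothing in the data shown gives a reason for this difference between methoxy and methyl.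

From the compounds shown here alone, it remains open whether a 4-ethoxyphenyl or a 4-hydroxyphenyl group on this nitrogen would follow the 4-methoxyphenyl group or fall in with the other three. Going by these compounds, all four compounds also share the same chain and the same sulfonamide, so it is equally open whether a shorter chain, or a carboxylic acid in place of the sulfonamide, would move the number further than these aryl swaps do.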